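Hydrogen for chloro on a fused two-ring core

A few compounds are considered here, and "the series" means these few. Any claim that something is new, unique, unknown or untested is made for them only; others in the source may bear on it.

Measured compounds in a functional assay on EKVX cells (Homo sapiens) for cytotoxicity, read by sulforhodamine B assay, with a stated time of 48 h; a higher number here means a weaker inhibitor of growth, a lower number a stronger inhibitor of growth:
compound 1 `ClCc1ccc(Cn2cnc3c(Cl)ncnc32)cc1`, 2450 nM
compound 2 `ClCc1ccc(Cn2cnc3nc(Cl)nc(Cl)c32)cc1`, 1900 nM
compound 3 `ClCc1ccc(Cn2cnc3c(Cl)nc(Cl)nc32)cc1`, 17400 nM

Compound 4 `ClCc1ccc(Cn2cnc3ncnc(Cl)c32)cc1` has not yet been measured in this assay. It arises from compound 2 by the change (hydrogen in place of chloro on an aromatic carbon). The same change, (hydrogen in place of chloro on an aromatic carbon), is already on record between two measured compounds, where it gave a 7.1-fold lower number from compound 3 to compound 1 (0.85 log units; beyond the scatter). The difference between the core of compound 2 and the core of compound 3 is not broken down here. Compound 2 and compound 1 are close in value, within the usual scatter, while compound 3 stands well beyond it.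

For compound 4 the author expects a smaller step than the earlier one, a 1.9-fold lower number from compound 2 to compound 4 (0.28 log units; within the scatter), since compound 2 already sits near compound 1 with 2450 nM and the earlier step started from the much higher value of compound 3, 17400 nM. The estimate for compound 4 is therefore 1000 nM, with a plausible range from 300 nM to 3500 nM.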

Compound 4, concentration for 50% growth inhibition: 2230 nM
For compound 4 the middle estimate is 2.2-fold (0.35 log units) below the measured one; the measured number falls inside the stated range.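

In this assay, hydrogen in place of chloro on an aromatic carbon gave a 1.2-fold higher number from compound 2 to compound 4 (0.07 log units; within the scatter), so on this core the change made no readable difference. Set beside the earlier case, the same change does not carry over unchanged from one core to the other: the same change on two cores in this assay, a 7.1-fold lower number (0.85 log units; beyond the scatter) from compound 3 to compound 1 and a 1.2-fold higher number (0.07 log units; within the scatter) from compound 2 to compound 4, 8.3-fold (0.92 log units) apart, beyond the scatter of two such steps. This shows that, across these two pairs, the size of the step differs with the core on which the change is made, but two pairs give no rule for a further core and do not show which feature of the cores sets them apart.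

The compounds shown carry only chloro or hydrogen at the changed place, so the effect of an amine, a methoxy group or a longer chain there remains open. The chloromethyl group is present in all four compounds, which leaves open how a hydroxymethyl or plain methyl group in its place would read in this assay.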